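The source may report more compounds than this note shows. Statements on the series, on what has been measured and on what is new or still open speak of the compounds shown alone.

Measured in a functional assay for antagonist activity at Melanocortin receptor 4 (Homo sapiens), read by cAMP accumulation; a lower number here means a stronger inhibitor, a higher number a weaker inhibitor:

compound 1, `CCN(CC)CCCC(C)/N=C(/N)NC(=O)c1cccc(F)c1OCc1cc(Br)ccc1OC`: 530 nM
compound 2, `COc1ccc(Br)cc1CCc1c(F)cccc1C(=O)/N=C(\N)NCCN1CCCC1`: 4500 nM
compound 3, `CCN(CC)CCCC(C)/N=C(/N)NC(=O)c1cccc(F)c1CCc1ccc2ccccc2c1`: 1800 nM

Compound 2 carries the highest number of the three in this assay. Its gap to compound 3, the nearest, is beyond the scatter, and its gap to compound 1, the furthest, is wider still; among these three compound 2 is thus the weakest inhibitor as measured.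

Compound 4, `COc1ccc(Br)cc1CCc1c(F)cccc1C(=O)/N=C(\N)NCC1CCNCC1`, is the next compound of the series and remains to be measured. It keeps the core of compound 2 and changes only the basic amine end of the side chain: piperidin-4-yl in place of (pyrrolidin-1-yl)methyl on a saturated chain carbon bound to an amine nitrogen. The two compounds share the same set of atoms arranged differently.

For the measured compounds named here, no step between measured compounds changes this amine end in a comparable way, so there is no anchor in the data for the size or direction of the step. The change is small in scale and the expectation is for a step in this assay that stays near or only modestly beyond the scatter, with the direction open. Compound 4 is estimated at 3200 nM, with a range of 1100 nM to 9500 nM. The estimated step of a 1.4-fold lower number from compound 2 to compound 4 (0.15 log units; within the scatter) is therefore expected to be small.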

Compound 4, half-maximal inhibitory concentration: 31 nM
Beside the measured number, compound 4's estimate is 100-fold (2.01 log units) above it; the whole stated range lies above it.
By their numbers in this assay, from the lowest: compound 4; then compound 1; then compound 3; then compound 2.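

In this assay the amine end of the side chain proves a highly sensitive position: piperidin-4-yl in place of (pyrrolidin-1-yl)methyl, on a saturated chain carbon bound to an amine nitrogen, gives a 150-fold lower number from compound 2 to compound 4 (2.16 log units; beyond the scatter). The two groups match in size and content, each with 6 heavy atoms (5 carbon, 1 nitrogen), so a step of this size arises with no change in atom count; what differs is how those atoms are joined, with a six-membered ring in place of a five-membered one and 1 hydrogen-bond donor in place of 0. Nothing available bears on which of these differences accounts for the step.

Open, going by these compounds, is whether the hydrogen-bond donor or the ring and its attachment carries the step, which a methyl group on the nitrogen of piperidin-4-yl or a (piperidin-3-yl)methyl end could help separate. Also open, on these data alone, is whether (piperidin-4-yl)methyl gives a step of similar size on the core of compound 1, and whether a longer chain carrying piperidin-4-yl keeps it.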